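Benzyl to tert-butyl on the double-bonded nitrogen

A few compounds are considered here, and "the series" means these few. Any claim that something is new, unique, unknown or untested is made for them only; others in the source may bear on it.

Compound 1 `COc1ccc(-n2cc(/C=[N+](\[O-])Cc3ccccc3)nn2)cc1` stands only at a limit: in a functional assay on PC-3 cells (Homo sapiens) for inhibition, read by MTT assay, with a stated time of 24 h (on this read-out lower numbers stand for stronger inhibition and higher numbers for weaker inhibition), compound 1 gives > 100000 nM, which is a limit of the assay and not a number. Compound 2 `[O-]/[N+](=C\c1cn(-c2ccc(C(F)(F)F)cc2)nn1)Cc1ccccc1` likewise gives > 100000 nM in this assay, again a limit. The step from compound 1 to compound 2, a step that the two limits leave unreadable from compound 1 to compound 2, is therefore unreadable. The change to compound 3 `COc1ccc(-n2cc(/C=[N+](\[O-])C(C)(C)C)nn2)cc1` is tert-butyl in place of benzyl on a double-bonded nitrogen. No readable measured step bears on it; both values shown sit at the limit of > 100000 nM in this assay, at which 2 of the 2 values shown sit. The expected step is a step that the limit leaves unreadable from compound 1 to compound 3, with no movement beyond the scatter foreseen. For compound 3 the estimated value is 150000 nM, in the range 40000 nM to 600000 nM.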

Compound 3, half-maximal inhibitory concentration: 23800 nM
Beside the measured number, compound 3's estimate is 6.3-fold (0.80 log units) above it, and the stated range ends above it.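

In this assay, going by these compounds alone, the double-bonded nitrogen is the first place where a change can be read: tert-butyl in place of benzyl gives an at least 4.2-fold lower number from compound 1 to compound 3 (0.62 log units; beyond the scatter). This step gives only a minimum size, because compound 1 stands at a limit: the limit of > 100000 nM in this assay, at which 2 of the 3 values shown sit. The step from methoxy to trifluoromethyl cannot be read.

Still open, as far as these compounds go, is whether tert-butyl acts the same way with trifluoromethyl in place of methoxy. Also open, from the compounds shown here alone, is what an isopropyl or a cyclohexyl group would do on that nitrogen.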